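Working notes: three measured analogues, compound 4 pending

The compounds below may be only part of what the source reports. "The series", "measured", "known", "first", "only" and "open" are said of these compounds alone.

Values in a functional assay on SW480 cells (Homo sapiens) for antiproliferative activity, read by MTT assay, with a stated time of 48 h; on this read-out lower numbers stand for stronger inhibition and higher numbers for weaker inhibition:
Compound 1 `O=c1cc(-n2cc(COc3ccnc4ccc(Br)cc34)nn2)c2cc(Br)ccc2o1`: 17000 nM
Compound 2 `COC(=O)c1ccccc1OCc1cn(-c2cc(=O)oc3ccc(Br)cc23)nn1`: 20200 nM
Compound 3 `O=c1cc(-n2cc(COc3ccccc3Br)nn2)c2cc(Br)ccc2o1`: 20100 nM

Compound 3 sits with the other two inside the usual scatter: a 1.0-fold lower number from compound 2 to compound 3 (0.00 log units; within the scatter), and against compound 1 the two values show no separation either. Compound 4 `O=c1cc(-n2cc(COc3ccc(F)cc3)nn2)c2cc(Br)ccc2o1` differs from compound 3 in one place: 4-fluorophenyl in place of 2-bromophenyl on an oxygen on a saturated carbon. Going by the values given here, no measured step changes this aryl group, so the only step in hand, the flat one from compound 2 to compound 3 on another phenyl, is an indirect guide; the series so far shows no movement in this assay at all. Compound 4 is therefore expected to stay within the scatter, a 1.1-fold lower number from compound 3 to compound 4 (0.04 log units; within the scatter). Compound 4 is estimated at 18500 nM, range 8000 nM to 45000 nM.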

Compound 4, half-maximal inhibitory concentration: 1770 nM
The estimate for compound 4 lay 10-fold (1.02 log units) above the measured number; measured number below the stated range.
By their numbers in this assay, from the lowest: compound 4; then compounds 1, 3 and 2 (each within the scatter of the next).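

In this assay, going by these compounds alone, the aryl group on this oxygen is the first place where one change moves the number: 4-fluorophenyl in place of 2-bromophenyl gives an 11-fold lower number from compound 3 to compound 4 (1.06 log units; beyond the scatter). The flat step a 1.0-fold lower number from compound 2 to compound 3 (0.00 log units; within the scatter) had shown no such sensitivity, though it changed a substituent on the same phenyl while keeping its place. No data at hand bear on the cause of the new step.

The halogen and its place change together here, so their shares in the step cannot be separated. From the compounds shown here alone, how a plain phenyl or a 4-bromophenyl group would read remains open.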